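The source may hold more compounds than are shown below. What is called first, only, known or untested is meant among the compounds shown, and "the series" means these compounds.

Three compounds were measured in an in vitro assay on LLC-PK1 cells for displacement of a labelled ligand from growth hormone secretagogue receptor type 1 (Homo sapiens) (on this read-out lower numbers stand for stronger inhibition and higher numbers for weaker inhibition), and a fourth awaits its number. Compound 1 `COc1ccc(Cn2c(CCc3c[nH]c4ccccc34)nnc2[C@H](NC(=O)c2ccccn2)c2c[nH]c3ccccc23)cc1` and compound 2 `COc1ccc(Cn2c(CCc3ccccc3)nnc2[C@H](NC(=O)c2ccccn2)c2c[nH]c3ccccc23)cc1` share a core carrying a 4-methoxybenzyl group; in this assay compound 2 gives 0.7 nM, and compound 1 gives 1.9 nM. Between them stands one change, (1H-indol-3-yl in place of phenyl on a saturated chain carbon, two bonds along the chain from an aromatic carbon), and that change brought a 2.7-fold higher number from compound 2 to compound 1 (0.43 log units; beyond the scatter).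

Compound 3 `O=C(N[C@H](c1c[nH]c2ccccc12)c1nnc(CCc2ccccc2)n1-c1ccccc1)c1ccccn1` differs from compound 2 in its core: phenyl in place of 4-methoxybenzyl on an aromatic nitrogen. That change brought a 150-fold higher number from compound 2 to compound 3 (2.18 log units; beyond the scatter), so that in this assay compound 3 gives 105 nM, the highest number among the three measured compounds.

Compound 4 `O=C(N[C@H](c1c[nH]c2ccccc12)c1nnc(CCc2c[nH]c3ccccc23)n1-c1ccccc1)c1ccccn1` is not yet measured. It differs from compound 3 by 1H-indol-3-yl in place of phenyl on a saturated chain carbon, two bonds along the chain from an aromatic carbon, which is the same change already seen from compound 2 to compound 1, made this time on the core of compound 3 rather than that of compound 2, and it occurs twice among the compounds shown. If the change behaves as it did before, the author expects a step of about a 2.7-fold higher number from compound 3 to compound 4 (0.43 log units; beyond the scatter), resting on the earlier 2.7-fold higher number from compound 2 to compound 1 (0.43 log units; beyond the scatter) and on the value of compound 3, 105 nM. Whether the change transfers unaltered onto the other core is not known from these compounds alone, so the range is kept wide. In this assay compound 4 is thus expected to give about 280 nM, between 100 nM and 800 nM.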

Compound 4, half-maximal inhibitory concentration: 160 nM
For compound 4 the middle estimate is 1.8-fold (0.24 log units) above the measured one, and the stated range covers the measured number.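

In this assay, 1H-indol-3-yl in place of phenyl on the core of compound 3 brought a 1.5-fold higher number from compound 3 to compound 4 (0.18 log units; within the scatter), and this step does not differ measurably from the one seen on the other core: the same change on two cores in this assay, a 2.7-fold higher number (0.43 log units; beyond the scatter) from compound 2 to compound 1 and a 1.5-fold higher number (0.18 log units; within the scatter) from compound 3 to compound 4, 1.8-fold (0.25 log units) apart, within the scatter of two such steps. Phenyl in place of 4-methoxybenzyl on an aromatic nitrogen, now made on the compounds carrying 2-(1H-indol-3-yl)ethyl, brought an 84-fold higher number from compound 1 to compound 4 (1.93 log units; beyond the scatter), and this large step also held its size: the same change on two cores in this assay, a 150-fold higher number (2.18 log units; beyond the scatter) from compound 2 to compound 3 and an 84-fold higher number (1.93 log units; beyond the scatter) from compound 1 to compound 4, 1.8-fold (0.25 log units) apart, within the scatter of two such steps. Within these compounds each change therefore carried over from one core to the other, but both comparisons rest on the same closed set of four compounds in a single assay, so they count as one observation seen from two sides and do not show that either change would carry over to any further core.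

The compounds shown leave open whether the large step belongs to the methoxy group or to the carbon linking the ring to the aromatic nitrogen, which a plain benzyl group on that nitrogen would separate. They also leave open whether the same carry-over would hold for a longer chain, or for an amine or a carboxylic acid in place of the phenyl of the phenethyl group.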